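This account rests on a few compounds, and the source may have more. Where it says the series, first, only, none or still open, it means among the compounds named here.

Compound 1 `CC1(C)CC(=O)C2=C(C1)NC(c1ccccc1)=CC2c1ccc(Cl)cc1` and compound 2 `CC1(C)CC(=O)C2=C(C1)NC(c1ccccc1)=CC2c1ccc([N+](=O)[O-])cc1` share one core and differ in a single group. In an assay on isolated protein for inhibition of glucose-6-phosphatase catalytic subunit 1 (Homo sapiens), read by inositol phosphate accumulation, with a stated time of 30 min, tested at 100 uM (on this read-out higher numbers stand for more inhibition at the one concentration tested (going by the name of the read-out) and lower numbers for less inhibition), compound 1 gives 7.16%, while compound 2 is reported only as "not active" (no number reported), so no single number places compound 2 on this scale. Compound 3 `COc1ccc(C2C=C(c3ccccc3)NC3=C2C(=O)CC(C)(C)C3)cc1` is the next member, and the change from compound 2 is methoxy in place of nitro on an aromatic carbon. Among the measured compounds shown here, no measured step of this kind is available, and no shift in this assay beyond the usual scatter is expected from it. Compound 3 is therefore estimated to give about 7% in this assay, within 0% to 20%.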

Compound 3, a percentage reported as inhibition, at one concentration (the size of the read-out at that concentration, not a potency): "not active" (no number reported)
Compound 3: no number reported, so the estimate cannot be set against anything.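

Compound 2 and compound 3 are both reported only as "not active", so no step can be read between them. Nothing shown here bears on this result. The compounds shown leave open whether 4-nitrophenyl to 4-methoxyphenyl changes inhibition at all.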